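Replacing a Dimethylamino Group with Hydroxy on a Side Chain

The source may report more compounds than this note shows. Statements on the series, on what has been measured and on what is new or still open speak of the compounds shown alone.

Compound 1 `CN(C)CCCn1c(Cc2nn(C)c(=O)c3ccccc23)nnc1SCCCCCCCC(=O)Nc1ccc(Cl)cc1Cl` was tested in an assay on 32D cells for inhibition of interleukin-15 (Mus musculus), read by resazurin assay, with stated times of 30 min and 2.5 days, in the presence of a further agent that is not named here (on this read-out lower numbers stand for stronger inhibition and higher numbers for weaker inhibition), and gives 5500 nM. Compound 2 `Cn1nc(Cc2nnc(SCCCCCCCC(=O)Nc3ccc(Cl)cc3Cl)n2CCCO)c2ccccc2c1=O` differs from it only by hydroxy in place of dimethylamino on a saturated chain carbon, three bonds along the chain from an aromatic nitrogen. In this assay compound 2 gives only a limit, > 30000 nM. The step is therefore an at least 5.4-fold higher number from compound 1 to compound 2 (0.73 log units; beyond the scatter); its size is known only as a lower bound because compound 2 sits at the limit of > 30000 nM in this assay, at which 1 of the 3 values shown sits.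

Compound 3 `CN(C)CCCn1nc(Cc2nnc(SCCCCCCCC(=O)Nc3ccc(Cl)cc3Cl)n2C)c2ccccc2c1=O` is built from the same atoms as compound 1, joined differently, and the difference between the two cores is not broken down here. In this assay compound 3 gives 3200 nM, which lies within the usual scatter of the number for compound 1.

Compound 4 `Cn1c(Cc2nn(CCCO)c(=O)c3ccccc23)nnc1SCCCCCCCC(=O)Nc1ccc(Cl)cc1Cl` has not been measured. It differs from compound 3 by hydroxy in place of dimethylamino on a saturated chain carbon, three bonds along the chain from an aromatic nitrogen, the same kind of change as that from compound 1 to compound 2, at the same place. Starting from compound 3, a step of about a 6.3-fold higher number from compound 3 to compound 4 (0.80 log units; beyond the scatter) is expected, resting on the step measured from compound 1 to compound 2. In this assay compound 4 is therefore estimated at 20000 nM, with a range from 8000 nM to 60000 nM, and a real chance that only a limit is reported.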

Compound 4, half-maximal inhibitory concentration: > 30000 nM
Compound 4: a limit, no number; the forecaster's own chance of this, stated with the estimate: 45%; middle value at least 1.5-fold (0.17 log units) away from the limit.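

In this assay, hydroxy in place of dimethylamino gives weaker inhibition on the core of compound 3 as well, with an at least 9.3-fold higher number from compound 3 to compound 4 (0.97 log units; beyond the scatter), so the change points the same way on both cores shown. This does not show that the change has the same size on the two cores, since each step is known only as a lower bound: the same change on two cores in this assay, an at least 5.4-fold higher number (0.73 log units; beyond the scatter) from compound 1 to compound 2 and an at least 9.3-fold higher number (0.97 log units; beyond the scatter) from compound 3 to compound 4; the limit leaves it open whether they differ. As far as these compounds go, compound 2 and compound 4 are both reported only as limits and not as numbers, so how much weaker either of them is stays unknown: the limit of > 30000 nM in this assay, at which 2 of the 4 values shown sit.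

The compounds shown leave open whether another group at this place, such as a primary amine, a carboxylic acid or a longer chain ending in dimethylamino, would keep the inhibition seen with 3-(dimethylamino)propyl. They also leave open whether the same change would point the same way on any core beyond these two.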